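Swapping a benzylic ring for a short alkyl chain

The compounds below may be only part of what the source reports. "The series", "measured", "known", "first", "only" and "open" are said of these compounds alone.

Of the compounds shown here, three sharing one core have been tested in a functional assay on SMMC-7721 cells (Homo sapiens) for antiproliferative activity, read by CCK-8 assay, with a stated time of 48 h; on this read-out lower numbers stand for stronger inhibition and higher numbers for weaker inhibition. Compound 1 `CC(C)CSc1n[nH]c(-n2[se]c3ccccc3c2=O)n1` gives 35000 nM. Compound 2 `O=c1c2ccccc2[se]n1-c1nc(SCc2ccc(F)cc2)n[nH]1` gives 46100 nM. Compound 3 `O=c1c2ccccc2[se]n1-c1nc(SCc2ccccc2)n[nH]1` gives 32000 nM. Compound 2 carries the highest of the three numbers, but its nearest neighbour is compound 1 with a 1.3-fold higher number from compound 1 to compound 2 (0.12 log units; within the scatter), and its furthest is compound 3 with a 1.4-fold lower number from compound 2 to compound 3 (0.16 log units; within the scatter), so all three sit within the scatter of one another and no order among them can be claimed.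

Compound 4 `CCCSc1n[nH]c(-n2[se]c3ccccc3c2=O)n1` has not yet been measured in this assay. It differs from compound 2 as follows: ethyl in place of 4-fluorophenyl on a saturated chain carbon bound to a sulfur.

For the measured compounds named here, two measured steps bear on this change. The move from isopropyl to 4-fluorophenyl on the saturated chain carbon bound to a sulfur gave a 1.3-fold higher number from compound 1 to compound 2 (0.12 log units; within the scatter), and the move from isopropyl to phenyl at the same place gave a 1.1-fold lower number from compound 1 to compound 3 (0.04 log units; within the scatter); removing the fluoro gave a 1.4-fold lower number from compound 2 to compound 3 (0.16 log units; within the scatter). Going by the values given here, every exchange at this position so far has left the read-out within the scatter. He therefore expects compound 4 to show no step beyond the scatter, a 1.2-fold lower number from compound 2 to compound 4 (0.08 log units; within the scatter), and estimates its value in this assay at 38000 nM, within a range of 18000 nM to 80000 nM.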

Compound 4, half-maximal inhibitory concentration: 6020 nM
Beside the measured number, compound 4's estimate is 6.3-fold (0.80 log units) above it, and the stated range ends above it.
By their numbers in this assay, from the lowest: compound 4; then compounds 3, 1 and 2 (each within the scatter of the next).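

Until compound 4, every exchange on the saturated chain carbon bound to a sulfur had stayed within the scatter, and this position looked indifferent to what it carried; in this assay, ethyl in place of 4-fluorophenyl now gives a 7.7-fold lower number from compound 2 to compound 4 (0.88 log units; beyond the scatter), and ethyl in place of phenyl gives a 5.3-fold lower number from compound 3 to compound 4 (0.73 log units; beyond the scatter). The gain does not depend on losing an aromatic ring, since compound 1 has none and hydrogen in place of methyl on a saturated chain carbon bound to two saturated chain carbons still gives a 5.8-fold lower number from compound 1 to compound 4 (0.76 log units; beyond the scatter), which leaves compound 4, with its propyl on the sulfur, as the most potent of the four, apart from a branched chain and from both ring-bearing groups alike. Nothing at hand explains why this one small change in the chain separates compound 4 from the other three.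

As far as these compounds go, whether the lower number belongs to propyl alone or extends to a longer chain such as butyl, or to a shorter one such as methyl, remains open. From the compounds shown here alone, it is equally open whether a hydroxyl or an amine at the end of the propyl chain would keep the number of compound 4 or lose it.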